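Swapping a Cycloheptyl Amide for a Methylcyclohexyl Amide

The source may hold more compounds than are shown below. What is called first, only, known or untested is meant among the compounds shown, and "the series" means these compounds.

Compound 1 `O=C(NCC1CC1)c1cncc(N2CCCN(Cc3ccccc3)CC2)n1` and compound 2 `O=C(NC1CCCCCC1)c1cnc(N2CCCCC2)cn1` were both tested in an in vitro ADME assay on microsomes from liver (Homo sapiens) for metabolic stability; a lower number here means slower removal, a higher number faster removal of the compound. For compound 1 this assay gives > 440 mL.min-1.g-1, which is a limit of the assay rather than a number. Across the two measured compounds, one reading therefore sits at a limit (the limit of > 440 mL.min-1.g-1 in this assay, at which 1 of the 2 values shown sits). Compound 2 gives 62 mL.min-1.g-1 in this assay, the only numerical reading shown here. Compound 3 `C[C@H]1CC[C@H](NC(=O)c2cnc(N3CCCCC3)cn2)CC1` has not yet been measured. It differs from compound 2 in one place: 4-methylcyclohexyl in place of cycloheptyl on an amide-type nitrogen. Within the data shown here, no measured pair of compounds differs in just this way, so the size of this step is not known from the data. With one saturated carbon ring replaced by another, the change in this assay is expected to stay within the usual scatter or to lower clearance only slightly. Compound 3 is accordingly estimated to give 50 mL.min-1.g-1 in this assay, within a range from 20 mL.min-1.g-1 to 140 mL.min-1.g-1. The expected step is a 1.2-fold lower number from compound 2 to compound 3 (0.09 log units; within the scatter).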

Compound 3, intrinsic clearance in microsomes in the Homo sapiens assay: 50 mL.min-1.g-1
Estimate against measurement, compound 3: no gap at the digits printed; low and high end bracket the measured number.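

In the Homo sapiens assay, the swap of 4-methylcyclohexyl for cycloheptyl on the amide-type nitrogen gives a 1.2-fold lower number from compound 2 to compound 3 (0.09 log units; within the scatter), so this first readable step at this position shows that one saturated carbon ring can replace the other with no real change in clearance. In a physicochemical assay for lipophilicity (on this read-out higher numbers stand for higher lipophilicity and lower numbers for lower lipophilicity), compound 2 gives 3.9 and compound 3 gives 4.4, so the same swap does separate the two compounds, and in this one pair a rise in lipophilicity did not bring faster removal: the measured distribution coefficient of compound 2, 3.9, and of compound 3, 4.4, a number 0.50 log units higher (beyond the scatter)

Among these compounds, in the Homo sapiens assay compound 1 gives > 440 mL.min-1.g-1, which is a limit and not a number, and it differs from compound 2 in more than one place, so no step to it can be read. Going by these compounds, whether a ring carrying an amine or a carboxylic acid on this amide-type nitrogen would lower clearance remains open.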